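Swapping an Amide for a Sulfonamide on the Shared Core

The source may report more compounds than this note shows. Statements on the series, on what has been measured and on what is new or still open speak of the compounds shown alone.

Compound 1 `CN(C(=O)c1ccc(F)cc1)c1ccc2[nH]c(-c3n[nH]c4ccccc34)cc2n1` is the reference point here. In a functional assay on HL-60 cells (Homo sapiens) for antiproliferative activity, read by MTT assay, with a stated time of 72 h (on this read-out higher numbers stand for weaker inhibition and lower numbers for stronger inhibition), compound 1 gives 1210 nM, the lowest of the three numbers measured. Compound 2 `CN(C(=O)c1ccc([N+](=O)[O-])cc1)c1ccc2[nH]c(-c3n[nH]c4ccccc34)cc2n1` gives 6800 nM, and compound 3 `CN(C(=O)c1ccccc1)c1ccc2[nH]c(-c3n[nH]c4cc(Cl)ccc34)cc2n1` gives 5620 nM. Going by the values given here, the one single-point step recorded, a 5.6-fold higher number from compound 1 to compound 2 (0.75 log units; beyond the scatter), shows that changing the group on the benzoyl ring can weaken inhibition noticeably. Compound 4 `CN(c1ccc2[nH]c(-c3n[nH]c4ccccc34)cc2n1)S(=O)(=O)c1ccccc1` introduces a different kind of change: phenylsulfonyl in place of (4-fluorophenyl)carbonyl on a nitrogen on an aromatic ring. Among the compounds with values here, no measured pair tests a sulfonyl in place of a carbonyl, so the step from compound 1 to compound 2 bears on it only loosely, as a sign that this part of the molecule matters. The expected step is a 2.1-fold higher number from compound 1 to compound 4 (0.32 log units; beyond the scatter), leaning toward weaker inhibition but with wide uncertainty. Compound 4 is therefore estimated at 2500 nM, within 600 nM to 12000 nM.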

Compound 4, half-maximal inhibitory concentration: 3700 nM
Beside the measured number, compound 4's estimate is 1.5-fold (0.17 log units) below it, within the range that was stated.
By their numbers in this assay, from the lowest: compound 1; then compounds 4, 3 and 2 (each within the scatter of the next).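

In this assay, the exchange on this nitrogen gives a 3.1-fold higher number from compound 1 to compound 4 (0.49 log units; beyond the scatter), so inhibition here is weaker with phenylsulfonyl than with (4-fluorophenyl)carbonyl. The exchange replaces the carbonyl with a sulfonyl and also removes the fluorine, so this one step cannot separate the two changes. Nothing available explains the difference.

Still open, as far as these compounds go, is how a (4-fluorophenyl)sulfonyl group would compare, as it would isolate the carbonyl-to-sulfonyl change. Also open, from the compounds shown here alone, is how a group without an aromatic ring, such as a methylsulfonyl group, would behave on this nitrogen.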